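A few compounds are considered here, and "the series" means these few. Any claim that something is new, unique, unknown or untested is made for them only; others in the source may bear on it.

Working notes on a set of compounds sharing one core that carries two propargyloxy-bearing phenyl groups, tested in an assay on BTI-TN-5B1-4 cells for inhibition of Amine oxidase [flavin-containing] B (Homo sapiens), read by fluorescence and Amplex Red, using microsomes, with a stated time of 30 min; on this read-out higher numbers stand for weaker inhibition and lower numbers for stronger inhibition. Going by the values given here, compound 2 `C#CCOc1ccc(-c2cc(-c3ccc(OCC#C)cc3)nc(C)n2)cc1` gives 7830 nM, the lowest number of the three measured so far. Compound 3 `C#CCOc1ccccc1-c1cc(-c2ccccc2OCC#C)nc(N)n1` gives 11100 nM in this assay, a gap to compound 2 that lies within the scatter of repeated measurements. Compound 1 `C#CCOc1ccc(-c2cc(-c3ccccc3OCC#C)nc(N)n2)cc1` gives 22100 nM, a gap to compound 2 that lies beyond the scatter. Among the compounds with values here, no pair of measured compounds differs in a single place, so no isolated step is available.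

Compound 4 `C#CCOc1ccc(-c2cc(-c3ccc(OCC#C)cc3)nc(N)n2)cc1` is the next candidate: amino in place of methyl on an aromatic carbon. Compound 1 at 22100 nM and compound 3 at 11100 nM both carry the amino group that enters here and both give higher numbers than compound 2, yet each also differs from compound 2 in where the propargyloxy groups sit. On that basis a small move toward weaker inhibition is expected for compound 4, with a step inside the scatter also plausible. The expected step is a 1.5-fold higher number from compound 2 to compound 4 (0.19 log units; within the scatter). Compound 4 is therefore estimated at 12000 nM, with a range from 5000 nM to 30000 nM.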

Compound 4, half-maximal inhibitory concentration: 3300 nM
The estimate for compound 4 lay 3.6-fold (0.56 log units) above the measured number, outside the stated range (below it).
By their numbers in this assay, from the lowest: compound 4; then compounds 2, 3 and 1 (each within the scatter of the next, the first and the last beyond it).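

In this assay, going by these compounds alone, this is the first isolated step: with both propargyloxy groups held in place, amino in place of methyl on an aromatic carbon gives a 2.4-fold lower number from compound 2 to compound 4 (0.38 log units; beyond the scatter). Compounds 1 and 3 also carry the amino group but differ from compound 2 in more than one place, so their higher numbers could not show the effect of this change; at this position, between two ring nitrogen atoms, the amino group goes with stronger inhibition than the methyl group. Nothing measured here accounts for the step.

On these data alone, whether a dimethylamino group, a hydroxyl group or a longer chain at this position would extend the step or reverse it stays open. Also open, as far as these compounds go, is whether a methyl group would give the same step with the propargyloxy groups placed as in compound 1 or compound 3.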